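Furan-2-yl for pyridin-2-yl on two arrangements of one core

The source may hold more compounds than are shown below. What is called first, only, known or untested is meant among the compounds shown, and "the series" means these compounds.

Compound 1 `O=C(CCCCCCc1ccccc1)c1nc(-c2ccccn2)no1` gives 0.34 nM in an assay for inhibition of Fatty-acid amide hydrolase 1 (Rattus norvegicus), at pH 9.0; on this read-out higher numbers stand for weaker inhibition and lower numbers for stronger inhibition.
Compound 2 `O=C(CCCCCCc1ccccc1)c1nc(-c2ccco2)no1` gives 1 nM in this assay.
Compound 3 `O=C(CCCCCCc1ccccc1)c1noc(-c2ccccn2)n1` gives 1.1 nM in this assay.

Compound 1 and compound 3 are built from the same atoms joined differently; the difference between the two cores is not broken down here. From compound 1 to compound 2 the change is furan-2-yl in place of pyridin-2-yl on an aromatic carbon, and it gave a 2.9-fold higher number from compound 1 to compound 2 (0.47 log units; beyond the scatter). Compound 4 `O=C(CCCCCCc1ccccc1)c1noc(-c2ccco2)n1` has not yet been measured. It arises from compound 3 by furan-2-yl in place of pyridin-2-yl on an aromatic carbon. Among the measured compounds shown here, this is the same kind of change as the one from compound 1 to compound 2, but the surroundings differ: in compound 1 the carbon that carries the group sits between two ring nitrogen atoms, two ring bonds from the ring oxygen, whereas in compound 3 it sits next to the ring nitrogen and next to the ring oxygen, two ring bonds from the ring nitrogen. For compound 4 the expected step is a 2.9-fold higher number from compound 3 to compound 4 (0.46 log units; beyond the scatter), resting on the single earlier case, a 2.9-fold higher number from compound 1 to compound 2 (0.47 log units; beyond the scatter). Compound 4 is therefore estimated at 3.2 nM, expected to lie between 1.2 nM and 9 nM.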

Compound 4, inhibition constant: 8.5 nM
Beside the measured number, compound 4's estimate is 2.7-fold (0.42 log units) below it; the measured number falls inside the stated range.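

Replacing pyridin-2-yl with furan-2-yl again weakened inhibition, with a 7.7-fold higher number from compound 3 to compound 4 (0.89 log units; beyond the scatter), so the direction of the change carried over from the core of compound 1 to the core of compound 3. Among the compounds shown here, although the second step looks larger, the two steps in this assay cannot be told apart: the same change on two cores in this assay, a 2.9-fold higher number (0.47 log units; beyond the scatter) from compound 1 to compound 2 and a 7.7-fold higher number (0.89 log units; beyond the scatter) from compound 3 to compound 4, 2.6-fold (0.42 log units) apart, within the scatter of two such steps This shows that, on these two cores, the change had the same direction and a size that agrees within the scatter, but with only two pairs it does not show that the core has no influence, nor that the result would hold on any other core.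

The compounds shown leave open whether the same step would appear with a different group on that aromatic carbon, such as a phenyl ring, a thiophen-2-yl ring or a carboxylic acid. They also leave open whether it would survive a shorter chain leading to the phenyl ring.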